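This account rests on a few compounds, and the source may have more. Where it says the series, first, only, none or still open, it means among the compounds named here.

Measured so far in a functional assay on the whole organism for inhibition, with Cavia porcellus as the target; a lower number here means that less compound is needed, a higher number that more compound is needed for the effect:
- Compound 1 `COc1ccccc1OCC1SCCN1C(C)=O`: 46 mg/kg
- Compound 2 `CCOC(=O)CCC(=O)N1CCSC1COc1ccccc1OC`: 24 mg/kg

Compound 2, at 24 mg/kg, cannot be separated from compound 1, since the two numbers lie within the scatter of each other. The next compound, compound 3 `COc1ccccc1OCC1SCCN1C(=O)C(C)(C)C(=O)O`, has not yet been measured. It carries 1-carboxy-1-methylethyl in place of 2-(ethoxycarbonyl)ethyl on a carbonyl carbon.

Among the compounds with values here, only one measured step bears on this change, since it also alters the group on that carbonyl carbon: a 1.9-fold lower number from compound 1 to compound 2 (0.28 log units; within the scatter). That step stayed within the scatter, so changes at this place have so far moved this assay little. Neither measured compound carries a carboxy group, however, so the data offer no direct guide to its effect, and the uncertainty is wide. The expected change is therefore small, tilted slightly towards needing more compound, and may not exceed the scatter: a 1.5-fold higher number from compound 2 to compound 3 (0.16 log units; within the scatter) is the estimated step. For compound 3 the estimated dose is 35 mg/kg, with an expected range from 12 mg/kg to 100 mg/kg.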

Compound 3, dose for half-maximal effect: 34 mg/kg
Compound 3: middle estimate off by 1.0-fold (0.01 log units), on the high side; low and high end bracket the measured number.
By their numbers in this assay, from the lowest: compounds 2, 3 and 1 (each within the scatter of the next).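

In this assay, 1-carboxy-1-methylethyl in place of 2-(ethoxycarbonyl)ethyl gives a 1.4-fold higher number from compound 2 to compound 3 (0.15 log units; within the scatter), and the same group in place of methyl gives a 1.4-fold lower number from compound 1 to compound 3 (0.13 log units; within the scatter). The earlier compounds shown here held no carboxy group, so the new information is that a free carboxylic acid can sit on this carbonyl carbon, whose other neighbour is an amide-type nitrogen in a ring, without a shift that can be told from the scatter, whether the comparison is with a small methyl or with a chain ending in an ethyl ester. The data give no explanation for this flat result.

The step from the ester chain to the acid also changes the branching of the chain, so the two changes cannot be separated; a straight chain ending in a carboxylic acid, set against the ethyl ester of the same length, would pull them apart. On these data alone, whether an amine at this place, or a much longer chain, would move the dose beyond the scatter also remains open.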